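The source may hold more compounds than are shown below. What is called first, only, known or untested is meant among the compounds shown, and "the series" means these compounds.

Compound 1, `CC(C)(C)OC(=O)Nc1ccc(C#CCCCCC(=O)c2ncc(-c3ccccn3)o2)cc1`, gives 23 nM in an assay for inhibition of Fatty-acid amide hydrolase 1 (Rattus norvegicus); a higher number here means a weaker inhibitor, a lower number a stronger inhibitor.
Compound 2, `COC(=O)c1ccccc1CCCCCCC(=O)c1ncc(-c2ccccn2)o1`, gives 1 nM in this assay.
Compound 3, `O=C(CCCCCCc1ccc2ccccc2c1)c1ncc(-c2ccccn2)o1`, gives 11 nM in this assay.

Of these three, compound 2 has the lowest number in this assay. Compound 3 stands nearest to it, and compound 1 furthest, and both gaps lie beyond the usual scatter of the measurement, so compound 2 can be called the strongest inhibitor of the three. All three share the same core; they differ only in what hangs at the far end of the chain.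

The next compound keeps the core and chain of compound 2 and changes one group on the aromatic ring at the end. Compound 4, `CS(=O)(=O)c1ccccc1CCCCCCC(=O)c1ncc(-c2ccccn2)o1`, carries methylsulfonyl in place of methoxycarbonyl on an aromatic carbon.

Among the measured compounds shown here, no measured pair shows this exact exchange, so there is nothing to lean on except the values of compounds 1 to 3, which show that the end group matters by more than the scatter. The step from compound 2 to compound 4 in this assay is expected to be a small rise, a 3.0-fold higher number from compound 2 to compound 4 (0.48 log units; beyond the scatter), not much beyond the scatter. Compound 4 is therefore estimated at 3 nM, with a range from 1 nM to 12 nM.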

Compound 4, inhibition constant: 37 nM
Estimate against measurement, compound 4: 12-fold (1.09 log units) below; measured number above the stated range.
By their numbers in this assay, from the lowest: compound 2; then compound 3; then compounds 1 and 4 (each within the scatter of the next).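

Exchanging methoxycarbonyl for methylsulfonyl on this aromatic carbon, ortho to a large group, gives in this assay a 37-fold higher number from compound 2 to compound 4 (1.57 log units; beyond the scatter) and so costs far more than the scatter of the measurement, even though the two groups match in their counts of heavy atoms and hydrogen-bond acceptors, and neither has a donor or a net charge. The earlier compounds shown here differ from one another in more than one place, so they could show only that the far end of the chain matters as a whole; this pair isolates a single group at a single position and shows that binding strength depends heavily on which group sits there, even when those counts are unchanged. Nothing available bears on the reason for this large step.

Going by these compounds, whether a carboxylic acid, a primary amide or a nitrile on this same aromatic carbon would stay close to compound 2 or fall towards compound 4 remains open. On these data alone, it is also open whether methoxycarbonyl or methylsulfonyl would behave the same way on another carbon of the ring, or with a shorter or longer chain.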